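Swapping a fused indole for a vinylphenyl arm

The source may report more compounds than this note shows. Statements on the series, on what has been measured and on what is new or still open speak of the compounds shown alone.

Of the compounds shown here, three built on one shared core have been measured in a functional assay on B16-F0 cells (Mus musculus) for inhibition, read by CCK-8 assay, with a stated time of 48 h; on this read-out higher numbers stand for weaker inhibition and lower numbers for stronger inhibition. Compound 1 `COc1cc(-c2ccnc3cc(-c4ccc(C)cc4)nn23)cc(OC)c1OC` carries a 4-methylphenyl on the core and gives 21 nM. Compound 2 `COc1cc(-c2ccnc3cc(-c4ccc(-c5cnn(C)c5)cc4)nn23)cc(OC)c1OC` carries a 1-methyl-1H-pyrazol-4-yl in place of that methyl and gives 1240 nM. Compound 3 `COc1cc(-c2ccnc3cc(-c4ccc5c(ccn5C)c4)nn23)cc(OC)c1OC` carries a 1-methyl-1H-indol-5-yl in place of the 4-methylphenyl and gives 48 nM, the second highest of the three numbers. Of the known steps, a 59-fold higher number from compound 1 to compound 2 (1.77 log units; beyond the scatter) was large, while a 2.3-fold higher number from compound 1 to compound 3 (0.36 log units; beyond the scatter) was modest.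

Compound 4 `C=Cc1ccc(-c2cc3nccc(-c4cc(OC)c(OC)c(OC)c4)n3n2)cc1` differs from compound 3 at one place: 4-vinylphenyl in place of 1-methyl-1H-indol-5-yl on an aromatic carbon. The entering 4-vinylphenyl, like the 4-methylphenyl of compound 1, is one six-membered aromatic ring of carbon only, so compound 1 with 21 nM is the closest guide, and the step is expected to run a little downward, near the reverse of a 2.3-fold higher number from compound 1 to compound 3 (0.36 log units; beyond the scatter). On that basis compound 4 is estimated at 30 nM, within 10 nM to 100 nM, which would mean an expected step of a 1.6-fold lower number from compound 3 to compound 4 (0.20 log units; within the scatter).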

Compound 4, half-maximal inhibitory concentration: 788 nM
Compound 4: middle estimate off by 26-fold (1.42 log units), on the low side; the measured number lies above the stated range.
By their numbers in this assay, from the lowest: compound 1; then compound 3; then compounds 4 and 2 (each within the scatter of the next).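

In this assay, vinyl in place of methyl gives a 38-fold higher number from compound 1 to compound 4 (1.57 log units; beyond the scatter), so a small change at the far end of the aryl arm can cost much of the inhibition, even though both arms carry one six-membered aromatic ring of carbon only. Size alone does not set the outcome, since the fused 1-methyl-1H-indol-5-yl arm has more heavy atoms than 4-vinylphenyl, yet the change from the former to the latter gives a 16-fold higher number from compound 3 to compound 4 (1.22 log units; beyond the scatter). Two quite different groups on the arm, vinyl and 1-methyl-1H-pyrazol-4-yl, land together, with a 1.6-fold lower number from compound 2 to compound 4 (0.20 log units; within the scatter).

No measurement shown here accounts for these differences. From the compounds shown here alone, it remains open whether an ethyl group, which keeps the two carbons of vinyl but loses the double bond, would behave like methyl or like vinyl, and the same holds for a methoxy group or an amine.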